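Chloro to Nitro: Expected Cytotoxicity of Compound 4

The compounds below may be only part of what the source reports. "The series", "measured", "known", "first", "only" and "open" are said of these compounds alone.

Three measured compounds share one core and differ only in the aryl group on an amine nitrogen in a ring: compound 1 `COc1ccccc1N1CCN(CC(=O)N2CCN(c3nnc(-c4ccc(C)cc4)c(-c4ccc(C)cc4)n3)CC2)CC1`, compound 2 `COc1ccc(N2CCN(CC(=O)N3CCN(c4nnc(-c5ccc(C)cc5)c(-c5ccc(C)cc5)n4)CC3)CC2)cc1` and compound 3 `Cc1ccc(-c2nnc(N3CCN(C(=O)CN4CCN(c5ccc(Cl)cc5)CC4)CC3)nc2-c2ccc(C)cc2)cc1`. In an ADME assay on NIH3T3 cells (Mus musculus) for cytotoxicity, read by MTT assay, with a stated time of 24 h (on this read-out lower numbers stand for stronger inhibition and higher numbers for weaker inhibition), compound 1 gives 133000 nM, compound 2 gives 116000 nM, and compound 3 gives 567000 nM, the highest of the three. The steps of a 4.3-fold higher number from compound 1 to compound 3 (0.63 log units; beyond the scatter) and a 4.9-fold higher number from compound 2 to compound 3 (0.69 log units; beyond the scatter) were modest yet beyond the scatter, whereas a 1.1-fold lower number from compound 1 to compound 2 (0.06 log units; within the scatter) lay within it. Compound 4 `Cc1ccc(-c2nnc(N3CCN(C(=O)CN4CCN(c5ccc([N+](=O)[O-])cc5)CC4)CC3)nc2-c2ccc(C)cc2)cc1` arises from compound 3 by nitro in place of chloro on an aromatic carbon. Among the measured compounds shown here, no measured step swaps chloro for nitro; the steps into compound 3 only show that this aryl group can move this assay modestly. Compound 4 is therefore expected to sit near compound 3, with a 1.6-fold lower number from compound 3 to compound 4 (0.21 log units; within the scatter) as a guess. Compound 4 is estimated at 350000 nM, within 120000 nM to 1000000 nM.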

Compound 4, half-maximal inhibitory concentration: > 844000 nM
Compound 4 was reported as a limit; the forecaster's own chance of this, stated with the estimate: 20%; at least 2.4-fold (0.38 log units) between middle value and limit.
By their numbers in this assay, from the lowest: compounds 2 and 1 (each within the scatter of the next); then compound 3. At a limit, above all of these: compound 4.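

Compound 4 is reported only as a limit in this assay: the limit of > 844000 nM in this assay, at which 1 of the 4 values shown sits. Swapping chloro for nitro gives an at least 1.4-fold higher number from compound 3 to compound 4 (0.17 log units; that floor lies within the scatter), so these two groups cannot yet be told apart, and the true size of this change stays unknown. Against the methoxy compounds, the result is clearer: an at least 7.2-fold higher number from compound 2 to compound 4 (0.86 log units; beyond the scatter) and an at least 6.3-fold higher number from compound 1 to compound 4 (0.80 log units; beyond the scatter), which extends the gap already seen with chloro to a second group at this position.

Still open, as far as these compounds go, is how an amine or a carboxylic acid on this aromatic carbon would compare.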